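Aryl swap on the oxadiazole-linked nitroimidazole series

This account rests on a few compounds, and the source may have more. Where it says the series, first, only, none or still open, it means among the compounds named here.

Compound 1 `COc1ccc(-c2nnc(SCCn3c([N+](=O)[O-])cnc3C)o2)cc1` is the reference point. For the measured compounds named here, in a functional assay on MCF7 cells (Homo sapiens) for cytotoxicity, read by MTT assay, with a stated time of 48 h (a lower number here means a stronger inhibitor, a higher number a weaker inhibitor), compound 1 gives 10600 nM, the lowest of the two numbers measured so far. Going by the values given here, its only measured neighbour is compound 2 `COc1ccc(-c2nnc(SCCn3c([N+](=O)[O-])cnc3C)o2)c(O)c1`, which in this assay gives 21800 nM; the step of a 2.1-fold higher number from compound 1 to compound 2 (0.31 log units; beyond the scatter), hydroxy in place of hydrogen on an aromatic carbon, is the sole structural change with a known outcome.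

Compound 3 `Cc1ncc([N+](=O)[O-])n1CCSc1nnc(-c2ccccn2)o1` has not been measured. Compared with compound 1 the change is pyridin-2-yl in place of 4-methoxyphenyl on an aromatic carbon. Among the compounds with values here, no measured step touches this kind of exchange: the one known step concerns an added hydroxy on the 4-methoxyphenyl group, not replacement of that group by pyridin-2-yl, so it offers no direct guide. With nothing to push the expectation either way, a step near the scatter is expected, a 1.2-fold higher number from compound 1 to compound 3 (0.09 log units; within the scatter), possibly a little weaker given that the only tested alteration of the aryl part, compound 2 at 21800 nM, gave a higher number.

For compound 3 in this assay the estimate is 13000 nM, within a range from 5000 nM to 35000 nM.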

Compound 3, half-maximal inhibitory concentration: 39100 nM
Beside the measured number, compound 3's estimate is 3.0-fold (0.48 log units) below it; measured number outside the range, above it.
By their numbers in this assay, from the lowest: compound 1; then compounds 2 and 3 (each within the scatter of the next).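

In this assay, replacing 4-methoxyphenyl with pyridin-2-yl on the aromatic carbon of the five-membered ring gives a 3.7-fold higher number from compound 1 to compound 3 (0.57 log units; beyond the scatter), so this position responds to an exchange of the whole aryl group and not only to a substituent added to it. Together with the added hydroxy, which gives a 2.1-fold higher number from compound 1 to compound 2 (0.31 log units; beyond the scatter), both single changes to the aryl part of compound 1 raise the number, and compound 1 keeps the lowest value among the three compounds. No measurement at hand accounts for either step.

Still open, on these data alone, is whether the step from the aryl exchange belongs to the loss of the methoxy group or to the entry of the ring nitrogen of pyridin-2-yl; a plain phenyl group at this position would separate the two. Also open, as far as these compounds go, is how the number would respond to an amine or a carboxylic acid on the aryl ring, and whether any change to the rest of the shared core moves it at all.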